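Extending a pyrrole amide to an indole amide

The source may report more compounds than this note shows. Statements on the series, on what has been measured and on what is new or still open speak of the compounds shown alone.

Four compounds share one core, and they differ only in the group attached to the carbonyl carbon of an amide. Compound 1 `CCc1ccc(C(=O)Nc2ccc3nc(N4CCN(CC)CC4)cc(C)c3c2)cc1` carries a 4-ethylphenyl group there and gives 3060 nM in a functional assay on MCF7 cells (Homo sapiens) for antiproliferative activity, read by MTT assay, with a stated time of 72 h; on this read-out higher numbers stand for weaker inhibition and lower numbers for stronger inhibition. Compound 2 `CCN1CCN(c2cc(C)c3cc(NC(=O)c4cccc(F)c4)ccc3n2)CC1` carries a 3-fluorophenyl group, and in this assay compound 2 gives 8920 nM. Compound 3 `CCN1CCN(c2cc(C)c3cc(NC(=O)c4ccc[nH]4)ccc3n2)CC1` carries a 1H-pyrrol-2-yl group, and in this assay compound 3 gives 14700 nM, the highest of the three numbers; its gap to compound 2 lies within the usual scatter, while its gap to compound 1 is beyond it.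

Compound 4 `CCN1CCN(c2cc(C)c3cc(NC(=O)c4cc5ccccc5[nH]4)ccc3n2)CC1` is the unmeasured compound. The change from compound 3 is 1H-indol-2-yl in place of 1H-pyrrol-2-yl on a carbonyl carbon.

Within the data shown here, the steps that bear on this are a 4.8-fold higher number from compound 1 to compound 3 (0.68 log units; beyond the scatter) and a 1.6-fold higher number from compound 2 to compound 3 (0.22 log units; within the scatter): going from a larger six-membered aromatic group to the small pyrrole raised the number, modestly in one case and within the scatter in the other. Among the measured compounds shown here, the indole restores a six-membered ring while keeping the pyrrole, so a modest move back toward lower numbers is expected, though no measured step tests exactly this enlargement. For compound 4 the expected step is a 2.5-fold lower number from compound 3 to compound 4 (0.39 log units; beyond the scatter), giving an estimate of 6000 nM with a range from 2000 nM to 18000 nM.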

Compound 4, half-maximal inhibitory concentration: 2950 nM
Compound 4: the middle estimate sits 2.0-fold (0.31 log units) above what was measured; measured number inside the range.
By their numbers in this assay, from the lowest: compounds 4 and 1 (each within the scatter of the next); then compounds 2 and 3 (each within the scatter of the next).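

Fusing a six-membered aromatic ring of carbon only onto the pyrrole gives, in this assay, a clear gain (a 5.0-fold lower number from compound 3 to compound 4 (0.70 log units; beyond the scatter)), so this position on the carbonyl carbon accepts a two-ring group and the number responds to that enlargement, even though the count of hydrogen-bond donors in the group stays the same. The 1H-indol-2-yl group also separates from the 3-fluorophenyl group (a 3.0-fold lower number from compound 2 to compound 4 (0.48 log units; beyond the scatter)), while it cannot be told apart from the 4-ethylphenyl group (a 1.0-fold lower number from compound 1 to compound 4 (0.02 log units; within the scatter)), which shows that two quite different groups, one with a fused ring and one with a short chain on a single ring, can reach the same level here. No measurement at hand explains why the added ring changes the number. 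

The compounds shown do not reveal whether the gain comes from the added ring as such or from the larger size of the group, and they give no view of how far enlargement can go. Going by these compounds, what a carboxylic acid, an amine or a methoxy group placed on the 1H-indol-2-yl group would do to the number also stays open.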